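Sulfonyl Substituent Changes on a Phenoxyacetic Acid Series

A few compounds are considered here, and "the series" means these few. Any claim that something is new, unique, unknown or untested is made for them only; others in the source may bear on it.

Measured compounds:
Compound 1 `COCCNS(=O)(=O)c1ccc(C)c(C#Cc2cc(Cl)ccc2OCC(=O)O)c1` gives 3.6 nM in an assay on CHO cells for displacement of a labelled ligand from prostaglandin D2 receptor 2 (Homo sapiens), read by scintillation counting; on this read-out lower numbers stand for stronger inhibition and higher numbers for weaker inhibition.
Compound 2 `Cc1ccc(S(=O)(=O)NC(C)C)cc1C#Cc1cc(Cl)ccc1OCC(=O)O` gives 3.4 nM in this assay.
Compound 3 `Cc1ccc(S(=O)(=O)N2CCOCC2)cc1C#Cc1cc(Cl)ccc1OCC(=O)O` gives 3.6 nM in this assay.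

The three measured compounds share one core and differ only at the sulfonyl group. Compound 3 stands level with compound 1 at the digits shown, and these two are together the highest of the three numbers; its nearest neighbour is compound 1, and its furthest is compound 2, yet every gap lies within the scatter. The steps of a 1.1-fold lower number from compound 1 to compound 2 (0.02 log units; within the scatter), no change at the digits printed from compound 1 to compound 3 (within the scatter) and a 1.1-fold higher number from compound 2 to compound 3 (0.02 log units; within the scatter) all fall within the scatter, so exchanging one sulfonamide substituent for another has so far left the number unmoved.

Compound 4 `Cc1ccc(S(=O)(=O)CC(C)C)cc1C#Cc1cc(Cl)ccc1OCC(=O)O` has not been measured. The change from compound 3 is isobutyl in place of morpholin-4-yl on a sulfonyl sulfur. Among the compounds with values here, none of the measured steps removes the nitrogen from the sulfonyl group, so they bear on this change only loosely; the three steps within the scatter suggest that the sulfonyl substituent is tolerant of variation, but the data do not show what leaving the nitrogen out does. Compound 3 is therefore the only anchor, and its value 3.6 nM is the starting point. The estimate for compound 4 in this assay is 5 nM, with a range from 1.5 nM to 20 nM, which means an expected step of a 1.4-fold higher number from compound 3 to compound 4 (0.14 log units; within the scatter) that is not expected to clear the scatter with confidence.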

Compound 4, inhibition constant: 3 nM
Compound 4: middle estimate off by 1.7-fold (0.22 log units), on the high side; low and high end bracket the measured number.
By their numbers in this assay, from the lowest: compounds 4, 2, 1 and 3 (each within the scatter of the next).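

In this assay the sulfonyl sulfur no longer needs a nitrogen on it: with isobutyl there, a 1.2-fold lower number from compound 3 to compound 4 (0.08 log units; within the scatter) and a 1.1-fold lower number from compound 2 to compound 4 (0.05 log units; within the scatter) and a 1.2-fold lower number from compound 1 to compound 4 (0.08 log units; within the scatter) all lie within the scatter. The earlier compounds shown here varied the substituent only with that nitrogen in place, whereas this change also gives up the ring and the hydrogen-bond acceptor of morpholin-4-yl with the number staying within the scatter. Nothing measured on these compounds accounts for this tolerance. The compounds shown leave open whether a chain ending in an amine or a carboxylic acid, or a phenyl ring, would be accepted on the sulfonyl sulfur. They also leave open whether the same tolerance would hold if the shared core were changed elsewhere.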